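The source may hold more compounds than are shown below. What is called first, only, known or untested is meant among the compounds shown, and "the series" means these compounds.

Compound 3 `COc1cc(Nc2ncc(C(F)(F)F)c(N3Cc4cccc(N(C)S(C)(=O)=O)c4C3)n2)cc(OC)c1` carries a 3,5-dimethoxyphenyl on a nitrogen on an aromatic ring of the shared core. In a functional assay on U-87MG ATCC cells for antiproliferative activity against U-87 MG (Homo sapiens), read by spectrophotometry, with a stated time of 2 days (a lower number here means a stronger inhibitor of growth, a higher number a weaker inhibitor of growth), compound 3 gives only a limit of the assay, > 30000 nM. The two other compounds known in this assay stand at the same limit. Compound 1 `CN(c1cccc2c1CN(c1nc(Nc3ccc(C(F)(F)F)cc3)ncc1C(F)(F)F)C2)S(C)(=O)=O` gives in this assay a limit, > 30000 nM. Compound 2 `CN(c1cccc2c1CN(c1nc(Nc3ccc(Cl)c(C(F)(F)F)c3)ncc1C(F)(F)F)C2)S(C)(=O)=O` likewise reaches only a limit in this assay, > 30000 nM. All three values therefore rest at the limit of > 30000 nM in this assay, at which 3 of the 3 values shown sit, and the steps between them cannot be read: a step that the two limits leave unreadable from compound 1 to compound 2, a step that the two limits leave unreadable from compound 1 to compound 3 and a step that the two limits leave unreadable from compound 2 to compound 3 all remain of unknown size. Compound 4 `Cc1ccc(Nc2ncc(C(F)(F)F)c(N3Cc4cccc(N(C)S(C)(=O)=O)c4C3)n2)c(Cl)c1` differs from compound 3 in one place: 2-chloro-4-methylphenyl in place of 3,5-dimethoxyphenyl on a nitrogen on an aromatic ring. The earlier steps shown here bear on this change only in that each exchange of the group on that nitrogen left the compound at the limit, so no direction and no size of step in this assay can be drawn from them. On this basis the expected step is a number no higher from compound 3 to compound 4 (the limit leaves the size open), that is, no readable shift in this assay. Compound 4 is estimated to give in this assay 30000 nM, with a range from 10000 nM to 100000 nM, and most probably again only a limit.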

Compound 4, concentration for 50% growth inhibition: > 30000 nM
Compound 4: only a limit was reported; the forecaster's own chance of this, stated with the estimate: 80%; the middle value lies on the limit itself.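

Compound 4 gives in this assay only a limit of the assay, > 30000 nM. The steps linking compound 4 with compound 1, compound 2 and compound 3 therefore cannot be read, and all four compounds stand together: the limit of > 30000 nM in this assay, at which 4 of the 4 values shown sit. The compounds shown leave open whether any group on that nitrogen changes growth inhibition in this assay.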